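Swapping 2-Aminophenyl for Hydroxy on the Amide Nitrogen

The source may hold more compounds than are shown below. What is called first, only, known or untested is meant among the compounds shown, and "the series" means these compounds.

Compound 1 `Nc1ccccc1NC(=O)c1ccc(CNCc2nc(-c3ccc(C(F)(F)F)cc3)no2)cc1`: 19700 nM
Compound 2 `Nc1ccccc1NC(=O)c1ccc(CNCc2nc(-c3ccc(Cl)cc3)no2)cc1`: 6810 nM

In a functional assay on HCT-116 cells (Homo sapiens) for inhibition, read by MTT assay, with a stated time of 72 h (a lower number here means a stronger inhibitor, a higher number a weaker inhibitor), compound 2 holds the lowest of the two numbers; compound 1 sits higher, and the step between them, a 2.9-fold lower number from compound 1 to compound 2 (0.46 log units; beyond the scatter), is modest. Compound 3 `O=C(NO)c1ccc(CNCc2nc(-c3ccc(Cl)cc3)no2)cc1` differs from compound 2 by hydroxy in place of 2-aminophenyl on an amide-type nitrogen. Among the compounds with values here, the single measured step concerns chloro in place of trifluoromethyl on an aromatic carbon and leaves the amide-type nitrogen untouched, so no measured step bears on the present change. Compound 3 is therefore estimated, with wide uncertainty, at 2000 nM (range 300 nM to 12000 nM). The expected step is a 3.4-fold lower number from compound 2 to compound 3 (0.53 log units; beyond the scatter), its direction uncertain.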

Compound 3, half-maximal inhibitory concentration: 30200 nM
Estimate against measurement, compound 3: 15-fold (1.18 log units) below; measured number outside the range, above it.
By their numbers in this assay, from the lowest: compound 2; then compounds 1 and 3 (each within the scatter of the next).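

Within the data shown here, this is the first measured change on the amide-type nitrogen, and in this assay hydroxy in place of 2-aminophenyl gives a 4.4-fold higher number from compound 2 to compound 3 (0.65 log units; beyond the scatter). The number at this position therefore responds to the group on that nitrogen, and here 2-aminophenyl gives the lower number. Nothing measured accounts for this step.

On these data alone, whether a plain phenyl or a 2-hydroxyphenyl on the same nitrogen would keep the number of compound 2 remains open. So does whether hydroxy gives a step of similar size and direction when trifluoromethyl replaces chloro.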